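Methoxy in place of chloro on the aromatic amide

A few compounds are considered here, and "the series" means these few. Any claim that something is new, unique, unknown or untested is made for them only; others in the source may bear on it.

Compound 1 `CC(C)(C)NC(=O)CCc1cccc2c1B(O)OC2`: > 100000 nM
Compound 2 `O=C(CCc1cccc2c1B(O)OC2)NC1CCCCC1`: > 100000 nM
Compound 3 `O=C(CCc1cccc2c1B(O)OC2)Nc1ccc(Cl)cc1`: 12000 nM

The entries for compound 1 and compound 2 are limits of a functional assay on HCT-116 cells (Homo sapiens) for antiproliferative activity, read by MTT assay, with a stated time of 72 h (a lower number here means a stronger inhibitor, a higher number a weaker inhibitor), not numbers. Compound 3 alone has a number, 12000 nM. Its place is set by two steps, an at least 8.3-fold lower number from compound 1 to compound 3 (0.92 log units; beyond the scatter) and an at least 8.3-fold lower number from compound 2 to compound 3 (0.92 log units; beyond the scatter). The third step, a step that the two limits leave unreadable from compound 1 to compound 2, adds nothing.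

Compound 4 `COc1ccc(NC(=O)CCc2cccc3c2B(O)OC3)cc1` differs from compound 3 in a single group, on the same aromatic carbon, para to a large group: methoxy in place of chloro on an aromatic carbon. Within the data shown here, no measured step changes this group, so the two readable steps show only that the 4-chlorophenyl amide reached a number where the other two amides did not. They give no size for a swap of chloro for methoxy. A small rise in the number is expected, possibly none beyond the scatter.

The expected change is a 1.7-fold higher number from compound 3 to compound 4 (0.22 log units; within the scatter). For compound 4 the estimated value is 20000 nM, within an expected range of 7000 nM to 60000 nM.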

Compound 4, half-maximal inhibitory concentration: 1700 nM
Estimate against measurement, compound 4: 12-fold (1.07 log units) above; the whole stated range lies above it.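

In this assay, among these compounds, methoxy in place of chloro on an aromatic carbon, para to a large group, gives a 7.1-fold lower number from compound 3 to compound 4 (0.85 log units; beyond the scatter), the only measured change at this position. The earlier compounds shown here showed only that the 4-chlorophenyl amide reached a number where the amides of compound 1 and compound 2 did not; this step shows that the group on the aromatic ring itself moves the number beyond the scatter, and that chloro is not needed for a number to be read. Compound 1 and compound 2 still give no size for comparison with this result, as their entries are limits and not numbers: the limit of > 100000 nM in this assay, at which 2 of the 4 values shown sit.

Going by these compounds, whether the lower number belongs to the oxygen or to the methyl of the methoxy group stays open, as does how a hydroxyl, an amine or a fluoro on the same carbon would read. The compounds shown also leave open whether a longer chain between the amide and the core would keep this step.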